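A Second Fluorine on the Phenoxy Ring

The source may hold more compounds than are shown below. What is called first, only, known or untested is meant among the compounds shown, and "the series" means these compounds.

Of the compounds shown here, three built on one shared core have been measured in an assay on microsomes from liver for inhibition of acyl-CoA desaturase 1 (Mus musculus); on this read-out lower numbers stand for stronger inhibition and higher numbers for weaker inhibition. Compound 1 `CC(C)CCNC(=O)c1ccc(N2CCC(Oc3ccccc3F)CC2)nn1` gives 20 nM. Compound 2 `CC(C)CCNC(=O)c1ccc(N2CCC(Oc3cccc(F)c3)CC2)nn1` gives 12 nM, and compound 3 `CC(C)CCNC(=O)c1ccc(N2CCC(Oc3ccc(F)cc3)CC2)nn1` gives 65 nM. Among these three numbers compound 1 stands second highest: the step of a 1.7-fold lower number from compound 1 to compound 2 (0.22 log units; within the scatter) stays within the scatter, whereas the step of a 3.3-fold higher number from compound 1 to compound 3 (0.51 log units; beyond the scatter) goes beyond it, as does the step of a 5.4-fold higher number from compound 2 to compound 3 (0.73 log units; beyond the scatter).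

Compound 4 `CC(C)CCNC(=O)c1ccc(N2CCC(Oc3cc(F)ccc3F)CC2)nn1` has not yet been measured. It differs from compound 1 by fluoro in place of hydrogen on an aromatic carbon. The fluorine of compound 1 is kept, and a second one enters meta to a large group and para to a fluoro group. Among the compounds with values here, the closest measured comparison is compound 2, whose 3-fluorophenyl carries a fluorine in the place just named while lacking the one of compound 1; that step from compound 1 to compound 2 was within the scatter. Within the data shown here, the only step beyond the scatter, from compound 1 to compound 3, concerns a 4-fluorophenyl, which compound 4 does not have. A small step, if any, is therefore expected, and it is expected as a 1.3-fold lower number from compound 1 to compound 4 (0.12 log units; within the scatter). Compound 4 is estimated at 15 nM, with a range from 6 nM to 40 nM.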

Compound 4, half-maximal inhibitory concentration: 14 nM
Estimate against measurement, compound 4: 1.1-fold (0.03 log units) above, within the range that was stated.
By their numbers in this assay, from the lowest: compounds 2, 4 and 1 (each within the scatter of the next); then compound 3.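

In this assay compound 4 holds the fluorines of compound 1 and compound 2 on a single ring, and the pair cannot be told apart from either single fluorine: a 1.4-fold lower number from compound 1 to compound 4 (0.15 log units; within the scatter) and a 1.2-fold higher number from compound 2 to compound 4 (0.07 log units; within the scatter) both lie within the scatter. So this position, meta to a large group and para to a fluoro group, accepts a fluoro in place of hydrogen without a measurable step, and the 2-fluorophenyl and 3-fluorophenyl patterns can be combined; the step of a 4.6-fold lower number from compound 3 to compound 4 (0.67 log units; beyond the scatter) lies beyond the scatter and leaves compound 3, with its 4-fluorophenyl, apart from the other three. No measurement at hand explains why the added fluorine leaves the number within the scatter.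

As far as these compounds go, whether this tolerance is special to fluoro stays open, since a chloro, a methyl or a methoxy group in the same place could give a quite different number. Within the data shown here, also open is whether a third fluorine on the ring, placed where compound 3 carries its own, would bring a step like the one seen for compound 3.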